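Cyclopentyl to phenyl on the weakly inhibiting compound 2

A few compounds are considered here, and "the series" means these few. Any claim that something is new, unique, unknown or untested is made for them only; others in the source may bear on it.

In a functional assay on PC-12 cells (Rattus norvegicus) for inhibition, read by sulforhodamine B assay (on this read-out lower numbers stand for stronger inhibition and higher numbers for weaker inhibition), compound 1 `O=C1N=C(O)S/C1=C\c1ccc(OCC2CCCCO2)cc1` gives 22000 nM, compound 2 `O=C1NC(=O)C(Cc2ccc(OCC3CCCC3)cc2)S1` gives 25000 nM and compound 3 `CCC(C)(C)Oc1ccc(/C=C2\SC(=O)NC2=O)cc1` gives 15000 nM. These three values lie within the scatter of one another, so compound 2 stands level with both neighbours and no order can be drawn among them.

The next compound to be read is compound 4 `O=C1NC(=O)C(Cc2ccc(OCc3ccccc3)cc2)S1`. It carries phenyl in place of cyclopentyl on a saturated chain carbon bound to an oxygen on an aromatic ring. The same difference can be read as cyclopentylmethyl to benzyl.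

Within the data shown here, no pair of measured compounds differs in one place, so no measured step bears directly on this change. Among the measured compounds shown here, the only guide is the narrow spread of the three values in this assay, despite their differing structures. A step beyond the scatter is therefore not expected, and the estimated change is a 1.3-fold lower number from compound 2 to compound 4 (0.10 log units; within the scatter). For compound 4 the expected value is 20000 nM, with an estimated range of 10000 nM to 40000 nM.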

Compound 4, half-maximal inhibitory concentration: > 100000 nM
Compound 4 gave a limit, no number (the forecaster's own chance of this, stated with the estimate: 10%); middle value at least 5.0-fold (0.69 log units) away from the limit.
By their numbers in this assay, from the lowest: compounds 3, 1 and 2 (each within the scatter of the next). At a limit, above all of these: compound 4.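

In this assay compound 4 reads > 100000 nM, which is a limit of the assay and not a number. Among these compounds, the change gives the only step so far, and it lies beyond the scatter: an at least 4.0-fold higher number from compound 2 to compound 4 (0.60 log units; beyond the scatter), so inhibition at this position does not tolerate phenyl in place of cyclopentyl, even though the three earlier values sat level despite their differing structures. The step has a lower bound but no measured size: the limit of > 100000 nM in this assay, at which 1 of the 4 values shown sits.

The compounds shown compare only cyclopentyl and phenyl at this place, so they cannot separate the effect of aromatic character from that of this particular ring. As far as these compounds go, how cyclohexyl, a pyridine ring or a phenyl ring carrying an amine would read here remains open.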